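The source may hold more compounds than are shown below. What is called first, only, known or untested is meant among the compounds shown, and "the series" means these compounds.

Of the compounds shown here, three on the shared core have been measured in a functional assay for inhibition, with Rattus norvegicus as the target; on this read-out higher numbers stand for weaker inhibition and lower numbers for stronger inhibition. Compound 1 `CCC(C)(C)/N=c1\c(O)c(O)\c1=N/Cc1c(Cl)cccc1Cl` gives 280 nM, and compound 2 `CC(C)(C)/N=c1\c(O)c(O)\c1=N/Cc1ccc(F)cc1Cl` gives 1400 nM. Compound 3 `CCC(CC)/N=c1\c(O)c(O)\c1=N/Cc1ccc(C#N)cc1` gives 1300 nM, within the scatter of compound 2 and beyond the scatter above compound 1. Compound 4 `CCC(C)(C)/N=c1\c(O)c(O)\c1=N/Cc1ccc(C#N)cc1`, not yet measured, carries 1,1-dimethylpropyl in place of pentan-3-yl on a double-bonded nitrogen. For the measured compounds named here, no measured pair isolates this change. Compound 1 carries the same 1,1-dimethylpropyl and gives 280 nM, but it also differs from compound 4 elsewhere, so it offers only weak support. A modest expected step of a 1.9-fold lower number from compound 3 to compound 4 (0.27 log units; within the scatter) towards stronger inhibition, near the edge of the scatter, seems reasonable. For compound 4 the estimate is 700 nM, with an expected range of 250 nM to 2000 nM.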

Compound 4, half-maximal inhibitory concentration: 1100 nM
The estimate for compound 4 lay 1.6-fold (0.20 log units) below the measured number; low and high end bracket the measured number.
By their numbers in this assay, from the lowest: compound 1; then compounds 4, 3 and 2 (each within the scatter of the next).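

In this assay, for the compounds shown here, 1,1-dimethylpropyl in place of pentan-3-yl on a double-bonded nitrogen gives a 1.2-fold lower number from compound 3 to compound 4 (0.07 log units; within the scatter) as the first comparison that differs in one place only. On this read-out the two groups cannot be told apart at this position, so the exchange alone does not separate them. No measured property in hand bears on this result.

From the compounds shown here alone, whether a cyclopentyl ring or a straight pentyl chain on this nitrogen would give a step beyond the scatter remains open. So does the effect of a smaller group such as methyl.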